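The compounds below may be only part of what the source reports. "The series", "measured", "known", "first", "only" and "open" are said of these compounds alone.

Measured so far, in a functional assay on PANC-1 cells (Homo sapiens) for cytotoxicity, read by WST assay, with a stated time of 24 h; a lower number here means a stronger inhibitor, a higher number a weaker inhibitor:
compound 1, `O=C(/C=C\CCCCCCc1ccccc1)N1CCCCC1`: > 100000 nM
compound 2, `O=C(CCCCCCCCCCc1ccccc1)N1CCCCC1`: > 100000 nM

Both numbers above are limits of the assay rather than measured values. Compound 1 gives > 100000 nM in this assay, which is a limit and not a number. Compound 2 gives > 100000 nM in this assay, again a limit and not a number. For the measured compounds named here, compound 2 therefore stands exactly where the only other measured compound stands, at the limit of > 100000 nM in this assay, at which 2 of the 2 values shown sit. Going by the values given here, no step between two measured compounds exists here, so nothing yet shows how any structural change moves the read-out in this assay.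

Compound 3, `COc1ccc(CCCCCCCCC(=O)N2CCCCC2)cc1`, has not been measured. It differs from compound 2 by 4-methoxyphenyl in place of phenethyl on a saturated chain carbon, eight bonds along the chain from a carbonyl carbon. Since both known values sit at the limit, the expectation for compound 3 in this assay is no step beyond the scatter, that is a number no higher from compound 2 to compound 3 (the limit leaves the size open). Compound 3 is accordingly estimated to give about 100000 nM, with a range from 30000 nM to 300000 nM, and most likely it too will be reported only as a limit.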

Compound 3, half-maximal inhibitory concentration: 89300 nM
For compound 3 the middle estimate is 1.1-fold (0.05 log units) above the measured one; the measured number falls inside the stated range.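

In this assay compound 3 gives 89300 nM, the only real number among the three compounds shown, so putting 4-methoxyphenyl in place of phenethyl on a saturated chain carbon, eight bonds along the chain from a carbonyl carbon, yields a reading that can be reported as a number. Compound 2 gives > 100000 nM, which is a limit and not a number. The change therefore gives an at least 1.1-fold lower number from compound 2 to compound 3 (0.04 log units; that floor lies within the scatter), and this is only a floor, so it does not show that the change makes a stronger inhibitor, and the true size of the step stays unknown because the comparison rests on a limit: the limit of > 100000 nM in this assay, at which 2 of the 3 values shown sit.

The swap replaces the whole phenethyl group, so the compounds shown do not separate the contribution of the methoxy group from that of the rest of the change. From the compounds shown here alone, it also remains open whether an amine or a carboxylic acid in place of the methoxy group, or a longer chain carrying the 4-methoxyphenyl, would bring the number clearly down from this level.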